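The compounds below may be only part of what the source reports. "The series", "measured", "known", "first", "only" and "open" are said of these compounds alone.

Measured in an ADME assay on MT4 cells (Homo sapiens) for cytotoxicity, read by MTT assay, with a stated time of 5 days; on this read-out higher numbers stand for lower toxicity in this test and lower numbers for higher toxicity in this test:
- compound 1 `COc1cc2nc([S+]([O-])CC(=O)Nc3ccc(C(F)(F)F)cc3)nc(Nc3c(C)cc(/C=C/C#N)cc3C)c2cc1OC`: 52200 nM
- compound 2 `COc1cc2nc([S+]([O-])CC(=O)Nc3ccc([N+](=O)[O-])cc3)nc(Nc3c(Cl)cc(/C=C/C#N)cc3Cl)c2cc1OC`: 92800 nM
- compound 3 `COc1cc2nc([S+]([O-])CC(=O)Nc3ccc(Cl)cc3)nc(Nc3c(Cl)cc(/C=C/C#N)cc3Cl)c2cc1OC`: 14400 nM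

Compound 3 has the lowest number of the three in this assay, beyond the scatter from both others, with compound 1 the nearest. Compound 4 `COc1cc2nc([S+]([O-])CC(=O)Nc3ccc(C(F)(F)F)cc3)nc(Nc3c(Cl)cc(/C=C/C#N)cc3Cl)c2cc1OC` has not yet been measured. It differs from compound 3 in one place, with trifluoromethyl in place of chloro on an aromatic carbon, para to a large group (trifluoromethyl in place of chloro on an aromatic carbon). For the measured compounds named here, one measured step touches this place: a 6.4-fold lower number from compound 2 to compound 3 (0.81 log units; beyond the scatter), modest and beyond the scatter. Compound 1 carries the same trifluoromethyl at 52200 nM, but it also differs from compound 4 elsewhere. A modest move to a higher number is therefore expected, though the evidence is thin. The estimated change is a 2.2-fold higher number from compound 3 to compound 4 (0.35 log units; beyond the scatter). For compound 4 the expected value is 32000 nM, with an estimated range of 13000 nM to 80000 nM.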

Compound 4, half-maximal cytotoxic concentration: 22000 nM
For compound 4 the middle estimate is 1.5-fold (0.16 log units) above the measured one; measured number inside the range.
By their numbers in this assay, from the lowest: compounds 3 and 4 (each within the scatter of the next); then compounds 1 and 2 (each within the scatter of the next).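

At this position of the 4-chlorophenyl group, trifluoromethyl and chloro are not separated in this assay (a 1.5-fold higher number from compound 3 to compound 4 (0.18 log units; within the scatter)). Nitro does stand apart from trifluoromethyl (a 4.2-fold lower number from compound 2 to compound 4 (0.63 log units; beyond the scatter)), so the earlier gap between nitro and chloro is not a general split between chloro and any other group here. With trifluoromethyl held constant, changing the group on the aromatic-ring nitrogen also moves the number (a 2.4-fold lower number from compound 1 to compound 4 (0.38 log units; beyond the scatter)).

Going by these compounds, whether an amine or a carboxylic acid at this position would follow nitro or chloro remains open. No measurement bears on why these steps differ.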